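The source may report more compounds than this note shows. Statements on the series, on what has been measured and on what is new or still open speak of the compounds shown alone.

Of the compounds shown here, three share the same ethoxyphenyl amide end and have been measured in a functional assay on CCRF-CEM cells (Homo sapiens) for cytotoxicity, read by resazurin assay, with a stated time of 48 h; on this read-out lower numbers stand for stronger inhibition and higher numbers for weaker inhibition. Compound 1 `CCOc1ccc(NC(=O)c2c(N)n[nH]c2NC)cc1` gives 7900 nM. Compound 2 `CCN/C(SC)=C(/C#N)C(=O)Nc1ccc(OCC)cc1` carries an open-chain ethylamino group in place of the ring of compound 1; in this assay compound 2 gives 9890 nM. Compound 3 `C=CCNc1[nH]nc(N)c1C(=O)Nc1ccc(OCC)cc1` gives 6560 nM. All three numbers lie within the scatter of one another, so compound 2 can be placed neither ahead of nor behind compound 1 or compound 3 in this assay; its number is simply one of three that cannot be told apart.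

Compound 4 `CCOc1ccc(NC(=O)/C(C#N)=C(\NC)SC)cc1` has not yet been measured. It differs from compound 2 by hydrogen in place of methyl on a saturated chain carbon bound to an amine nitrogen, so the ethylamino group of compound 2 becomes a methylamino group. Among the measured compounds shown here, the only measured step that alters a chain on a nitrogen of this kind is the change from compound 1 to compound 3, which gave a 1.2-fold lower number from compound 1 to compound 3 (0.08 log units; within the scatter). That step sits on a different core, but it is the nearest guide available, and it suggests that trimming or extending such a chain leaves the number where it was.

Compound 4 is therefore expected to show a 1.0-fold lower number from compound 2 to compound 4 (0.02 log units; within the scatter) in this assay, no step beyond the scatter. The estimate for compound 4 is 9500 nM, with a range from 4500 nM to 20000 nM.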

Compound 4, half-maximal inhibitory concentration: 9940 nM
Estimate against measurement, compound 4: 1.0-fold (0.02 log units) below; the range from low to high includes it.
By their numbers in this assay, from the lowest: compounds 3, 1, 2 and 4 (each within the scatter of the next).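

Changing ethylamino to methylamino gives a 1.0-fold higher number from compound 2 to compound 4 (0.00 log units; within the scatter) in this assay and is the first change shown at this position on the open-chain compounds themselves. Among the compounds shown here, it also runs in the shortening direction, as methyl gives way to hydrogen on a saturated chain carbon bound to an amine nitrogen, whereas the only earlier chain step, a 1.2-fold lower number from compound 1 to compound 3 (0.08 log units; within the scatter), added vinyl on another core. Among the compounds shown, both chain changes therefore stay within the scatter, one lengthening and one shortening, although no measurement gives a reason for this result.

Still open, going by these compounds, is whether a much longer chain such as hexyl, or a chain ending in a carboxylic acid or an amine, would move the number on this nitrogen beyond the scatter. The compounds shown also leave open whether the open-chain compounds would respond to a vinyl extension as the core of compound 1 did.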